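Replacing the 2-methoxyphenyl group of compound 3

A few compounds are considered here, and "the series" means these few. Any claim that something is new, unique, unknown or untested is made for them only; others in the source may bear on it.

Compound 1 `COc1cc2c(Oc3ccc(NC(=O)Nc4ccccc4C(F)(F)F)cc3)ccnc2cc1OCCCCCCC(=O)NO`: 5280 nM
Compound 2 `COc1cc2c(Oc3ccc(NC(=O)Nc4ccc(C)cc4C)cc3)ccnc2cc1OCCCCCCC(=O)NO`: 5490 nM
Compound 3 `COc1ccccc1NC(=O)Nc1ccc(Oc2ccnc3cc(OCCCCCCC(=O)NO)c(OC)cc23)cc1`: 16200 nM

In a functional assay on A549 cells (Homo sapiens) for antiproliferative activity, read by MTT assay (on this read-out higher numbers stand for weaker inhibition and lower numbers for stronger inhibition), compound 3 gives the highest of the three numbers, 16200 nM, which makes it the weakest inhibitor so far. Compound 4 `COc1cc2c(Oc3ccc(NC(=O)NNC(=O)c4cccc(C)c4)cc3)ccnc2cc1OCCCCCCC(=O)NO` carries ((3-methylphenyl)carbonyl)amino in place of 2-methoxyphenyl on an amide-type nitrogen. The closest evidence comes from exchanges on that same nitrogen or its aromatic group: a 3.1-fold higher number from compound 1 to compound 3 (0.49 log units; beyond the scatter) and a 3.0-fold higher number from compound 2 to compound 3 (0.47 log units; beyond the scatter), both modest, while a 1.0-fold higher number from compound 1 to compound 2 (0.02 log units; within the scatter) stayed within the scatter. None of these adds a carbonyl and a further nitrogen, so they guide only loosely. A small expected step towards a lower number follows, likely no larger than the scatter: a 1.8-fold lower number from compound 3 to compound 4 (0.26 log units; within the scatter). For compound 4 the estimated value is 9000 nM, with an expected range from 3000 nM to 27000 nM.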

Compound 4, half-maximal inhibitory concentration: 8190 nM
Beside the measured number, compound 4's estimate is 1.1-fold (0.04 log units) above it; the range from low to high includes it.
By their numbers in this assay, from the lowest: compounds 1, 2, 4 and 3 (each within the scatter of the next, the first and the last beyond it).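

In this assay, for the compounds shown here, the ((3-methylphenyl)carbonyl)amino group places a carbonyl and a further nitrogen where the earlier compounds carry their aromatic ring directly on the amide-type nitrogen. All three steps stay within the scatter (a 2.0-fold lower number from compound 3 to compound 4 (0.30 log units; within the scatter); a 1.5-fold higher number from compound 2 to compound 4 (0.17 log units; within the scatter); a 1.6-fold higher number from compound 1 to compound 4 (0.19 log units; within the scatter)), so this longer group fits the same range of numbers as the simple aromatic groups. Still open, going by these compounds, is whether a carboxylic acid or an amine in place of the methyl on this group would keep the number in that range. No other measurement here helps to explain this result.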